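This account rests on a few compounds, and the source may have more. Where it says the series, first, only, none or still open, it means among the compounds named here.

Compound 1 `CCCOC(=O)C1=C(C)NC(C)=C(C(=O)OC)C1c1csc(-c2ccc(Cl)cc2)n1` gives 5920 nM in an assay on isolated protein for antagonist activity at Voltage-dependent L-type calcium channel subunit alpha-1C (Cavia porcellus), with a stated time of 15 min (on this read-out higher numbers stand for weaker inhibition and lower numbers for stronger inhibition), the highest of the two numbers shown. Compound 2 `CCCOC(=O)C1=C(C)NC(C)=C(C(=O)OCC)C1c1csc(-c2ccc(Cl)cc2)n1` gives 4090 nM in this assay; the step of a 1.4-fold lower number from compound 1 to compound 2 (0.16 log units; within the scatter) lies within the scatter. Compound 3 `COC(=O)C1=C(C)NC(C)=C(C(=O)OC(C)c2ccccc2)C1c1csc(-c2ccc(Cl)cc2)n1` carries 1-phenylethyl in place of propyl on an oxygen next to a carbonyl group. For the measured compounds named here, the only measured step touches a different ester group and was small, so it bears only loosely on this change. Compound 3 is therefore expected to show a step of a 1.5-fold lower number from compound 1 to compound 3 (0.17 log units; within the scatter), no larger than the scatter. Compound 3 is estimated at 4000 nM, within 1500 nM to 12000 nM.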

Compound 3, half-maximal inhibitory concentration: 7620 nM
The estimate for compound 3 lay 1.9-fold (0.28 log units) below the measured number, within the range that was stated.
By their numbers in this assay, from the lowest: compounds 2, 1 and 3 (each within the scatter of the next).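

In this assay the exchange of propyl for 1-phenylethyl on an oxygen next to a carbonyl group gives a 1.3-fold higher number from compound 1 to compound 3 (0.11 log units; within the scatter) and so stays within the scatter. This position thus accepts a much larger group, with 8 heavy atoms instead of 3 and one six-membered aromatic ring, without a change beyond the scatter, which the small step at a different ester group could not show. No evidence on hand accounts for this result. On these data alone, whether an amine or a carboxylic acid on this chain would shift the number remains open, as does the effect of a longer chain ending in phenyl.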